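The source may report more compounds than this note shows. Statements on the series, on what has been measured and on what is new or still open speak of the compounds shown alone.

In an ADME assay on MT4 cells (Homo sapiens) for cytotoxicity, read by MTT assay (on this read-out lower numbers stand for higher toxicity in this test and higher numbers for lower toxicity in this test), three compounds built on a shared core have been measured. Compound 1 `Cc1cc(C)cc(S(=O)(=O)c2c(C(=O)NC(C)C(=O)NCCn3c(C)cnc3[N+](=O)[O-])[nH]c3ccc(Cl)cc23)c1` gives 16000 nM and compound 3 `Cc1cc(C)cc(S(=O)(=O)c2c(C(=O)NCC(=O)NC(C)c3ccccc3F)[nH]c3ccc(Cl)cc23)c1` gives 23000 nM, so these two values lie within the scatter of each other. Compound 2 `Cc1cc(C)cc(S(=O)(=O)c2c(C(=O)NC(C)c3ccco3)[nH]c3ccc(Cl)cc23)c1` gives > 54700 nM, which is a limit of the assay and not a number.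

Compound 4 `Cc1cc(C)cc(S(=O)(=O)c2c(C(=O)NC(C)C(=O)NC(C)c3ccccc3F)[nH]c3ccc(Cl)cc23)c1` has not yet been measured. It differs from compound 3 by methyl in place of hydrogen on a saturated chain carbon bound to an amide-type nitrogen and a carbonyl carbon. Going by the values given here, no measured pair of compounds shows this change on its own, so the expectation rests on a narrow base. The measured numbers are close together, with compound 1 at 16000 nM and compound 3 at 23000 nM, so no shift beyond the scatter is expected in this assay. The expected step is a 1.1-fold lower number from compound 3 to compound 4 (0.04 log units; within the scatter), which is within the scatter. For compound 4 the estimated value is 21000 nM, with an expected range from 10000 nM to 48000 nM.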

Compound 4, half-maximal cytotoxic concentration: 15200 nM
The estimate for compound 4 lay 1.4-fold (0.14 log units) above the measured number, within the range that was stated.
By their numbers in this assay, from the lowest: compounds 4, 1 and 3 (each within the scatter of the next). At a limit, above all of these: compound 2.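

In this assay the methyl on a saturated chain carbon bound to an amide-type nitrogen and a carbonyl carbon now has a measured step of its own: a 1.5-fold lower number from compound 3 to compound 4 (0.18 log units; within the scatter) on this single change. Going by these compounds alone, the change on the amide-type nitrogen gives a 1.1-fold lower number from compound 1 to compound 4 (0.02 log units; within the scatter) and likewise stays within the scatter, while (1-(2-fluorophenyl)ethyl)carbamoyl in place of furan-2-yl gives an at least 3.5-fold lower number from compound 2 to compound 4 (0.55 log units; beyond the scatter) as the only step here beyond the scatter. As far as these compounds go, compound 2 stands at a limit and not at a number, so the full size of that last step stays unknown: the limit of > 54700 nM in this assay, at which 1 of the 4 values shown sits.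

From the compounds shown here alone, whether an ethyl group, an amine or a carboxylic acid on this chain carbon would also stay within the scatter remains open. Also open, going by these compounds, is whether the methyl step would stay this small on a core carrying another group on the amide-type nitrogen.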